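A few compounds are considered here, and "the series" means these few. Any claim that something is new, unique, unknown or untested is made for them only; others in the source may bear on it.

Measured compounds in the series:

- compound 1, `NC(=O)C(CCn1ccnc1)(c1ccccc1)c1ccccc1`: 5.07 nM
- compound 2, `CCc1nccn1CCC(C(N)=O)(c1ccccc1)c1ccccc1`: 78.1 nM

In an assay on ileum with muscarinic acetylcholine receptor M3 (Cavia porcellus) as the target (a higher number here means a weaker inhibitor, a lower number a stronger inhibitor), compound 1 gives 5.07 nM, and compound 2 gives 78.1 nM. Among the compounds with values here, compound 2 therefore stands at the highest number of the two, with compound 1 as its only neighbour. Within the data shown here, the one step measured so far, a 15-fold higher number from compound 1 to compound 2 (1.19 log units; beyond the scatter), is the only step that bears on the next change.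

Compound 3, `CCCc1nccn1CCC(C(N)=O)(c1ccccc1)c1ccccc1`, is not yet measured. It differs from compound 2 by methyl in place of hydrogen on a saturated chain carbon, two bonds along the chain from an aromatic carbon. Among the measured compounds shown here, this extends the same chain that was introduced in the step from compound 1 to compound 2, one carbon further out, so that step is the only guide available. That step was large and towards a weaker inhibitor; a further lengthening of the same chain is expected to go the same way, though the size of a second step along a chain is not given by a single prior step. The expectation for compound 3 is a 1.7-fold higher number from compound 2 to compound 3 (0.22 log units; within the scatter), a smaller move than the measured one because of a 15-fold higher number from compound 1 to compound 2 (1.19 log units; beyond the scatter) being already large. The estimated value for compound 3 in this assay is 130 nM, within 45 nM to 400 nM.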

Compound 3, antagonist equilibrium constant: 177 nM
Compound 3: the middle estimate sits 1.4-fold (0.13 log units) below what was measured; measured number inside the range.
By their numbers in this assay, from the lowest: compound 1; then compound 2; then compound 3.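

In this assay the chain at this place can be lengthened further and the number still rises: ethyl to propyl gives a 2.3-fold higher number from compound 2 to compound 3 (0.36 log units; beyond the scatter) and stays beyond the scatter, so the direction of the first step continues past a single added group. Counted from hydrogen on the aromatic carbon, propyl gives a 35-fold higher number from compound 1 to compound 3 (1.54 log units; beyond the scatter) in total, and the added methyl contributes less than ethyl did in a 15-fold higher number from compound 1 to compound 2 (1.19 log units; beyond the scatter) so the larger part of the rise across these three compounds lies in the first step, and compound 3 extends the order without any compound going against it. Nothing available here bears on why the number rises along this chain.

Still open, as far as these compounds go, is whether a longer chain such as butyl carries the rise further, or whether a branched group such as isopropyl, or a hydroxyl or an amine on the chain, reads differently at this place. From the compounds shown here alone, only this assay is available, so whether the same order holds at another muscarinic receptor subtype also stays open.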